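Replacing a Ring with an Open-Chain Amide on a Shared Core

The source may report more compounds than this note shows. Statements on the series, on what has been measured and on what is new or still open speak of the compounds shown alone.

Compound 1 `CC(C)C(c1ccc(-c2ccc3cccc(F)c3c2)[nH]c1=O)N1CCN/C1=N\C#N`: 38 nM
Compound 2 `CC(C)C(c1nnc[nH]1)c1ccc(-c2ccc3cccc(F)c3c2)[nH]c1=O`: 21 nM
Compound 3 `CC(C)C(Cc1noc(=O)[nH]1)c1ccc(-c2ccc3cccc(F)c3c2)[nH]c1=O`: 70 nM

Three compounds share a core and differ only in the group carried on the saturated chain carbon. In a functional assay on CHO cells for antagonist activity at prostaglandin E2 receptor EP3 subtype (Homo sapiens), read by cAMP accumulation (on this read-out lower numbers stand for stronger inhibition and higher numbers for weaker inhibition), compound 3 gives 70 nM, the highest of the three numbers; compound 1 sits nearest with a 1.8-fold higher number from compound 1 to compound 3 (0.27 log units; within the scatter) and compound 2 furthest with a 3.3-fold higher number from compound 2 to compound 3 (0.52 log units; beyond the scatter), while a 1.8-fold lower number from compound 1 to compound 2 (0.26 log units; within the scatter) stays within the scatter.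

Compound 4 `CC(C)NC(=O)CC(c1ccc(-c2ccc3cccc(F)c3c2)[nH]c1=O)C(C)C` is the unmeasured neighbour of compound 3. The change is a group of 6 heavy atoms (4 carbon, 1 nitrogen, 1 oxygen; no ring) in place of a group of 6 heavy atoms (2 carbon, 2 nitrogen, 2 oxygen; one five-membered aromatic ring with 3 hetero atoms), on a saturated chain carbon, two bonds along the chain from an aromatic carbon: an isopropylcarbamoyl group, with no ring, replaces the five-membered aromatic ring with 3 hetero atoms.

All three measured steps swap groups at this same position, and each moved the number only modestly: two within the scatter, one just beyond. Nothing here ties the oxadiazolone ring or an open-chain amide to a sizeable shift, so a small step in either direction is the most that is expected. The expected step is a 1.2-fold lower number from compound 3 to compound 4 (0.07 log units; within the scatter). Compound 4 is therefore estimated at 60 nM in this assay, with a range from 25 nM to 150 nM.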

Compound 4, half-maximal inhibitory concentration: 15 nM
The estimate for compound 4 lay 4.0-fold (0.60 log units) above the measured number; the whole stated range lies above it.
By their numbers in this assay, from the lowest: compounds 4, 2, 1 and 3 (each within the scatter of the next, the first and the last beyond it).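

In this assay, this position accepts a group with no ring: on a saturated chain carbon, two bonds along the chain from an aromatic carbon, isopropylcarbamoyl gives a 4.7-fold lower number from compound 3 to compound 4 (0.67 log units; beyond the scatter), and the same open-chain amide also gives a 2.5-fold lower number from compound 1 to compound 4 (0.40 log units; beyond the scatter). The step of a 1.4-fold lower number from compound 2 to compound 4 (0.15 log units; within the scatter) stays within the scatter, so the amide side chain and 4H-1,2,4-triazol-3-yl cannot be told apart here, and a ring at this position is not required to reach this level among these four compounds. No measurement offered here accounts for the size of these steps.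

The compounds shown leave open how much of the result rests on the isopropyl group or on the amide hydrogen. A dimethylamide, a cyclopropylamide or a carboxylic acid at this place could settle that.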